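The compounds below may be only part of what the source reports. "The series", "measured", "known", "first", "only" and "open" are said of these compounds alone.

Measured compounds:
- compound 1, `O=C(/C=C1\CCc2ccc(F)cc21)NCC1CC1`, gives 21% in a functional assay on the whole organism with Rattus norvegicus as the target, at a dose of 20 mg/kg by the oral route; a lower number here means less inhibition, a higher number more inhibition at the dose given (going by the name of the read-out)
- compound 2, `O=C(/C=C1\CCc2ccc(F)cc21)NCCO`, gives 78% in this assay
- compound 3, `CON(C)C(=O)/C=C1\CCc2ccc(F)cc21`, gives 14% in this assay

Compound 3 stands lowest of the three numbers. Its nearest neighbour is compound 1, and the difference a number 7 percentage points lower from compound 1 to compound 3 (within the scatter) lies within the usual scatter, so the two cannot be told apart. Its furthest neighbour is compound 2, and the drop a number 64 percentage points lower from compound 2 to compound 3 (beyond the scatter) is large and well beyond the scatter.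

Compound 4, `O=C(/C=C1\CCc2ccc(F)cc21)N1CCC1`, differs from compound 3 in one place: azetidin-1-yl in place of methoxy(methyl)amino on a carbonyl carbon

Within the data shown here, two measured steps touch the same carbonyl carbon. The change a number 7 percentage points lower from compound 1 to compound 3 (within the scatter) was within the scatter, while a number 64 percentage points lower from compound 2 to compound 3 (beyond the scatter) was a large fall. Among the measured compounds shown here, neither involves azetidin-1-yl, so no measured step speaks directly to this change. With no donor or acceptor arriving and none lost that compound 3 relied on in a measurable way, no step beyond the scatter is expected, giving an expected a number 4 percentage points higher from compound 3 to compound 4 (within the scatter) in this assay. Compound 4 is therefore estimated at 18%, with a range from 0% to 45%.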

Compound 4, a percentage reported as inhibition, in the whole organism at one dose (the size of the read-out at that dose, not a potency): 0%
For compound 4 the middle estimate is 18 percentage points above the measured one, within the range that was stated.
By their numbers in this assay, from the lowest: compound 4; then compounds 3 and 1 (each within the scatter of the next); then compound 2.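

In this assay, azetidin-1-yl on the carbonyl carbon gives a result that the earlier groups at this position did not: compound 4 stands lowest of the four, with a number 14 percentage points lower from compound 3 to compound 4 (beyond the scatter) and a number 21 percentage points lower from compound 1 to compound 4 (beyond the scatter), both modest, although compound 1 and compound 3 could not be told apart. The gap to the compound carrying (2-hydroxyethyl)amino is far larger, with a number 78 percentage points lower from compound 2 to compound 4 (beyond the scatter), so that group remains the only one here with a high number. Nothing available explains why the small ring lowers the number.

On these data alone, it remains open whether a hydroxyl group on the four-membered ring, as in 3-hydroxyazetidin-1-yl, would bring the number back towards that of compound 2. As far as these compounds go, a longer chain, such as (3-hydroxypropyl)amino, or a six-membered ring such as morpholin-4-yl, is equally open.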